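The source may report more compounds than this note shows. Statements on the series, on what has been measured and on what is new or still open speak of the compounds shown alone.

Working notes on the series. In an assay for inhibition of serine/threonine-protein kinase PAK 4 (Homo sapiens), read by FRET and Z'-LYTE, with a stated time of 60 min, tested at 50 uM, in the presence of a further agent that is not named here (on this read-out lower numbers stand for a weaker effect and higher numbers for a stronger effect at the one concentration tested), compound 1 `CC(C)COC(=O)N1CCN(C(=O)c2nc(Nc3cc(C4CC4)[nH]n3)c3cc(Cl)ccc3n2)C[C@H]1C` gives 46.9%, and compound 2 `CC(C)C(=O)OCOC(=O)N1CCN(C(=O)c2nc(Nc3cc(C4CC4)[nH]n3)c3cc(Cl)ccc3n2)C[C@H]1C` gives 86.9%. Compound 2 stands highest of the two numbers shown; the step of a number 40 percentage points higher from compound 1 to compound 2 (beyond the scatter) is the only measured step and it is large. Compound 3 `C[C@@H]1CN(C(=O)c2nc(Nc3cc(C4CC4)[nH]n3)c3cc(Cl)ccc3n2)CCN1C(=O)OC(C)(C)C` is not yet measured. It differs from compound 2 by tert-butyl in place of ((isopropylcarbonyl)oxy)methyl on an oxygen next to a carbonyl group. Among the compounds with values here, this change runs counter to the one measured step: the tert-butyl that enters in compound 3 is closer to the isopropyl of compound 1 than to the ((isopropylcarbonyl)oxy)methyl of compound 2. Because the step of a number 40 percentage points higher from compound 1 to compound 2 (beyond the scatter) was large, the step expected in this assay from compound 2 to compound 3 is a number 36.9 percentage points lower from compound 2 to compound 3 (beyond the scatter), downward and beyond the scatter. Compound 3 is therefore estimated at 50%, with a range from 28% to 74%.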

Compound 3, a percentage reported as inhibition, at one concentration (the size of the read-out at that concentration, not a potency): 36.4%
For compound 3 the middle estimate is 13.6 percentage points above the measured one; the range from low to high includes it.
By their numbers in this assay, from the lowest: compound 3; then compound 1; then compound 2.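

With tert-butyl on the oxygen next to a carbonyl group, this assay gives a number 50.5 percentage points lower from compound 2 to compound 3 (beyond the scatter), so the high number of compound 2 is not kept by this second group made only of carbon and hydrogen. Tert-butyl in place of isobutyl gives a number 10.5 percentage points lower from compound 1 to compound 3 (beyond the scatter), so the two simple alkyl groups can be told apart at this position, though by a modest step compared with the large one on removing ((isopropylcarbonyl)oxy)methyl. No measurement shown accounts for either step.

Open, going by these compounds, is how much of the ((isopropylcarbonyl)oxy)methyl group is needed, for example whether acetoxymethyl, a methoxymethyl ether or a longer acyloxymethyl chain would keep the number of compound 2. Also open, on these data alone, is how an amine or a carboxylic acid at the end of this chain would read out, and whether the stronger and weaker effects seen at the one concentration tested would hold at other concentrations.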